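The source may report more compounds than this note shows. Statements on the series, on what has been measured and on what is new or still open speak of the compounds shown alone.

Measured compounds:
- compound 1, `COc1ccc(N2C(=O)N(Cc3ccc(F)cc3Cl)c3ccccc3S2(=O)=O)cc1OC`: > 2510 nM
- compound 2, `COc1cc(F)c(CN2C(=O)N(c3ccc(OC)c(OC)c3)S(=O)(=O)c3ccccc32)c(Cl)c1`: 0.398 nM
- compound 3, `COc1ccc(N2C(=O)N(Cc3ccccc3F)c3ccccc3S2(=O)=O)cc1OC`: 316 nM

In an assay on isolated protein for displacement of a labelled ligand from Orexin/Hypocretin receptor type 1 (Homo sapiens), with a stated time of 90 min (on this read-out higher numbers stand for weaker inhibition and lower numbers for stronger inhibition), compound 3 gives 316 nM, the highest of the two numbers available. Its nearest neighbour is compound 2, from which it differs by the benzyl-ring substitution, and the step runs a 790-fold higher number from compound 2 to compound 3 (2.90 log units; beyond the scatter). The value of compound 1 in this assay is only a limit, (the limit of > 2510 nM in this assay, at which 1 of the 3 values shown sits), and so carries no number.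

Compound 4, `COc1ccc(N2C(=O)N(Cc3c(F)cccc3Cl)c3ccccc3S2(=O)=O)cc1OC`, has not yet been measured. It differs from compound 3 by chloro in place of hydrogen on an aromatic carbon. Within the data shown here, no measured step makes exactly this change alone. The step of a 790-fold higher number from compound 2 to compound 3 (2.90 log units; beyond the scatter) removes the chloro together with a methoxy and is large; the step of an at least 7.9-fold lower number from compound 1 to compound 3 (0.89 log units; beyond the scatter) removes a chloro while moving the fluoro and is at least modest. Both point the same way: the chloro-bearing ring gives the lower number. The present change adds the chloro without the methoxy, so a lower number than compound 3 is expected, though less than the full span to compound 2.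

For compound 4 the expected value in this assay is 20 nM, with a range of 3 nM to 160 nM, which means a step of a 16-fold lower number from compound 3 to compound 4 (1.20 log units; beyond the scatter) is expected.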

Compound 4, inhibition constant: 7.94 nM
Compound 4: middle estimate off by 2.5-fold (0.40 log units), on the high side; the measured number falls inside the stated range.
By their numbers in this assay, from the lowest: compound 2; then compound 4; then compound 3. At a limit, above all of these: compound 1.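

In this assay, among these compounds, chloro in place of hydrogen on the 2-fluorobenzyl group now reads as a change on its own, a 40-fold lower number from compound 3 to compound 4 (1.60 log units; beyond the scatter), where the earlier steps carried it only together with other changes. Hydrogen in place of methoxy also reads alone, a 20-fold higher number from compound 2 to compound 4 (1.30 log units; beyond the scatter), so the methoxy of compound 2 matters in this assay even with the chloro and fluoro in place. The step of an at least 310-fold lower number from compound 1 to compound 4 (2.49 log units; beyond the scatter), for 2-chloro-6-fluorophenyl in place of 2-chloro-4-fluorophenyl, starts from a limit and not a number: the limit of > 2510 nM in this assay, at which 1 of the 4 values shown sits.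

From the compounds shown here alone, whether bromo or methyl can stand in for the chloro at this place remains open. Also open, going by these compounds, is whether ethoxy or a dimethylamino group can take the place of the methoxy, and how much the chloro contributes when the methoxy is present.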